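A few compounds are considered here, and "the series" means these few. Any claim that something is new, unique, unknown or untested is made for them only; others in the source may bear on it.

In a functional assay on cells (Platelet, Homo sapiens) for inhibition (a lower number here means a stronger inhibitor, a higher number a weaker inhibitor), compound 1 `CCNC(=O)c1ccc(-c2nn(Cc3ccccc3)c3ccccc23)cc1` gives 5640 nM. Compound 2 `CC(C)NC(=O)c1ccc(-c2nn(Cc3ccccc3)c3ccccc23)cc1` stands only at a limit of the assay, > 10000 nM. Compound 3 `CO/N=C\c1ccc(-c2nn(Cc3ccccc3)c3ccccc23)cc1` loses the isopropylcarbamoyl group of compound 2, and a group with no common name enters on the same aromatic carbon: a group of 4 heavy atoms (2 carbon, 1 nitrogen, 1 oxygen; no ring) in place of a group of 6 heavy atoms (4 carbon, 1 nitrogen, 1 oxygen; no ring), on an aromatic carbon. Among the compounds with values here, the only measured step nearby, an at least 1.7-fold higher number from compound 1 to compound 2 (0.24 log units; that floor lies within the scatter), alters the chain on the amide nitrogen and does not replace the group, so it guides weakly. A modest move to a lower number is expected, towards compound 1 at 5640 nM. The estimated step is an at least 1.4-fold lower number from compound 2 to compound 3 (0.15 log units; that floor lies within the scatter). Compound 3 is expected at 7000 nM, with an estimated range of 2000 nM to 20000 nM.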

Compound 3, half-maximal inhibitory concentration: > 10000 nM
Compound 3: a limit, no number; the forecaster's own chance of this, stated with the estimate: 40%; middle value at least 1.4-fold (0.15 log units) away from the limit.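

In this assay, swapping the amide group on this aromatic carbon for the group of compound 3, which has no hydrogen-bond donors, gives an at least 1.7-fold higher number from compound 1 to compound 3 (0.24 log units; that floor lies within the scatter). This replacement therefore shows no gain over the amide of compound 1, although the floor of that step stays within the scatter. The step between compound 2 and compound 3 cannot be read, because both stand at a limit: the limit of > 10000 nM in this assay, at which 2 of the 3 values shown sit.

Going by these compounds, how far compound 2 and compound 3 really lie from compound 1 stays open. Also open, on these data alone, is whether a carboxylic acid or an amine on this aromatic carbon would give a readable value.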